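The compounds below may be only part of what the source reports. "The series", "measured", "known", "first", "only" and "open" are said of these compounds alone.

Among the measured compounds shown here, in an ADME assay on microsomes from liver (Rattus norvegicus) for metabolic stability (on this read-out higher numbers stand for a longer-lived compound and lower numbers for a shorter-lived compound), compound 1 `COc1cc(OCc2csc(-c3ccc(C(F)(F)F)cc3)n2)c2cc(-c3cn4nc(OC)sc4n3)oc2c1` gives 1.42 h, the only firm number so far for this shared core. Compound 2 `COc1cc(OCc2cccc(-c3ccc(C(F)(F)F)cn3)c2)c2cc(-c3cn4nc(OC)sc4n3)oc2c1` reads > 2 h, which is a limit of the assay and not a number, and so it stands at the limit of > 2 h in this assay, at which 1 of the 2 values shown sits. Compound 3 `COc1cc(OCc2cccc(-c3cncnc3)c2)c2cc(-c3cn4nc(OC)sc4n3)oc2c1` follows from compound 2 by one structural change, (pyrimidin-5-yl in place of 5-(trifluoromethyl)pyridin-2-yl on an aromatic carbon), with pyrimidin-5-yl in place of 5-(trifluoromethyl)pyridin-2-yl on an aromatic carbon. For the measured compounds named here, no measured step in this assay sizes this change, so the expectation rests on a single anchor, compound 1 at 1.42 h. A modest fall in half-life is expected, of a size near the usual scatter, and the estimated step is an at least 1.3-fold lower number from compound 2 to compound 3 (0.12 log units; that floor lies within the scatter). For compound 3 the expected half-life is 1.5 h, with an estimated range of 0.7 h to 2 h.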

Compound 3, half-life: 0.117 h
The estimate for compound 3 lay 13-fold (1.11 log units) above the measured number; measured number below the stated range.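

Among the compounds shown here, until now, no measured step in this assay showed how much the group on this aromatic carbon matters. Replacing 5-(trifluoromethyl)pyridin-2-yl with pyrimidin-5-yl gives an at least 17-fold lower number from compound 2 to compound 3 (1.23 log units; beyond the scatter), so half-life in this series depends strongly on the group at this position. The true step may be larger still, as its starting value is a limit of the assay and not a number: the limit of > 2 h in this assay, at which 1 of the 3 values shown sits.

The change removes the trifluoromethyl group and alters the ring nitrogens together, and the compounds shown do not tell which of the two carries the fall. Also open, going by these compounds, is whether a pyrimidin-5-yl ring bearing trifluoromethyl, a plain pyridin-2-yl ring, or a phenyl ring with a methoxy group or an amine at this position would keep the longer half-life.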